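The compounds below may be only part of what the source reports. "The series", "measured", "known", "first", "only" and "open" are said of these compounds alone.

Compound 1 `CN(C1CCCc2ccccc21)C1CC(=O)c2ccccc21`: 13%
Compound 2 `C=CCN(C1CCCc2ccccc21)C1CC(=O)c2ccccc21`: 72%

In a functional assay on the whole organism (strain Wistar) for inhibition, with Rattus norvegicus as the target, with stated times of 48 h and 30 min, at a dose of 3 mg/kg by the intravenous route (a lower number here means less inhibition, a higher number more inhibition at the dose given (going by the name of the read-out)), compound 1 gives 13%, the lowest of the two numbers measured. Among the compounds with values here, its nearest neighbour is compound 2, which gives 72%; the step of a number 59 percentage points higher from compound 1 to compound 2 (beyond the scatter) is the only measured step, and it concerns the substituent on the amine nitrogen, not the aromatic ring.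

Compound 3 `COc1ccc2c(c1)C(=O)CC2N(C)C1CCCc2ccccc21` differs from compound 1 by methoxy in place of hydrogen on an aromatic carbon. Within the data shown here, no measured step bears on this change: the single step between compound 1 and compound 2 alters a different part of the molecule, and nothing measured shows what a substituent on this aromatic ring does in this assay. Among the measured compounds shown here, with no step to lean on, the expectation is that compound 3 stays near compound 1, with no step beyond the scatter, that is an expected step of a number 7 percentage points higher from compound 1 to compound 3 (within the scatter). Compound 3 is therefore estimated at 20%, in a range from 5% to 45%.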

Compound 3, a percentage reported as inhibition, in the whole organism at one dose (the size of the read-out at that dose, not a potency): 62%
Compound 3: the middle estimate sits 42 percentage points below what was measured; the measured number lies above the stated range.
By their numbers in this assay, from the lowest: compound 1; then compounds 3 and 2 (each within the scatter of the next).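

In this assay, methoxy in place of hydrogen on the aromatic carbon meta to a fused ring and para to a fused ring gives a number 49 percentage points higher from compound 1 to compound 3 (beyond the scatter) and so counts as a large step. Within the data shown here, until this result, only a change on the substituent at the amine nitrogen had been seen to move this read-out, whereas here the nitrogen substituent of compound 1 stays in place and a change on the aromatic ring alone moves it. Nothing available explains why this change has so large an effect.

Whether the gain belongs to methoxy itself or to this aromatic carbon remains open, as neither a hydroxyl group or a fluorine atom at the same place nor methoxy on another carbon of that ring is among the compounds shown. Also open, going by these compounds, is how methoxy would act together with the vinyl change seen in compound 2 on a single molecule.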